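Three Flat Readings and a Fourth Compound to Come

A few compounds are considered here, and "the series" means these few. Any claim that something is new, unique, unknown or untested is made for them only; others in the source may bear on it.

Compound 1 `Cc1nc(-c2ccc(Cl)cc2)sc1C(=O)CSc1nc(-c2ccc(Cl)c(Cl)c2)c(C#N)c(=O)[nH]1`: 101%
Compound 2 `Cc1nc(-c2ccccc2)sc1C(=O)CSc1nc(-c2ccc(Cl)c(Cl)c2)c(C#N)c(=O)[nH]1`: 98.6%
Compound 3 `COc1ccc(-c2nc(C)c(C(=O)CSc3nc(-c4ccc(Cl)c(Cl)c4)c(C#N)c(=O)[nH]3)s2)cc1`: 101%

In a functional assay on U-87MG ATCC cells for antiproliferative activity against U-87 MG (Homo sapiens), read by MTT assay, with a stated time of 48 h, tested at 5 uM (a higher number here means a weaker effect of the compound at the concentration tested, a lower number a stronger effect), compound 1 gives 101%. It stands level with compound 3 at the digits reported, and the two together hold the highest numbers of the three; the step of no change at the digits printed from compound 1 to compound 3 (within the scatter) is within the scatter, as is a number 2.4 percentage points lower from compound 1 to compound 2 (within the scatter), so none of the three compounds can be told apart by this read-out. All three show essentially no effect at the concentration tested.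

Compound 4 `COc1cccc(-c2nc(SCC(=O)c3sc(-c4ccc(Cl)cc4)nc3C)[nH]c(=O)c2C#N)c1` is the next compound in line. Its difference from compound 1 is 3-methoxyphenyl in place of 3,4-dichlorophenyl on an aromatic carbon. The measured steps, a number 2.4 percentage points lower from compound 1 to compound 2 (within the scatter), no change at the digits printed from compound 1 to compound 3 (within the scatter) and a number 2.4 percentage points higher from compound 2 to compound 3 (within the scatter), all concern a change on the other aromatic ring of the shared core, and each lies within the scatter. None of them touches the ring that changes here, so they bear on the new step only in a general way: three substituent changes on this scaffold left the read-out unmoved. With no measured step beyond the scatter, the expected step of a number 2 percentage points lower from compound 1 to compound 4 (within the scatter) is none beyond the scatter. Compound 4 is therefore estimated at 99%, with a range from 85% to 110%.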

Compound 4, a percentage reported as activity, at one concentration (the size of the read-out at that concentration, not a potency): 96.6%
Compound 4: middle estimate off by 2.4 percentage points, on the high side; the measured number falls inside the stated range.
By their numbers in this assay, from the lowest: compounds 4, 2, 1 and 3 (each within the scatter of the next).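

This is the first change shown at the aromatic carbon next to the ring nitrogen and ortho to a cyano group, and in this assay replacing 3,4-dichlorophenyl with 3-methoxyphenyl gives a number 4.4 percentage points lower from compound 1 to compound 4 (within the scatter). The read-out therefore does not separate these two groups at this position, so the flat picture seen on the other aromatic ring now extends to a second site on the shared core, though on the strength of this single pair. No accompanying data bear on this result.

From the compounds shown here alone, whether any group at this position can move the read-out remains open, and an amine, a carboxylic acid or a longer alkyl chain in place of the aromatic ring would put that to the test. Also open, going by these compounds, is how 3-methoxyphenyl at this position behaves when the other aromatic ring carries hydrogen, as in compound 2, or methoxy, as in compound 3, in place of the chloro group of compound 4.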